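The compounds below may be only part of what the source reports. "The series", "measured", "known", "first", "only" and "open" are said of these compounds alone.

Compound 1 `COc1cc2c(cc1CC=C(C)C)C(=O)C[C@@H](c1ccc(Oc3ccccc3)cc1)O2`: 53%
Compound 2 `COc1ccc([C@@H]2C/C(=N/OCc3cn(-c4ccc(NC(=O)c5ccccc5)cc4)nn3)c3cc(CC=C(C)C)c(OC)cc3O2)cc1`: 22%
Compound 3 `COc1cc2c(cc1CC1OC1(C)C)C(=O)C[C@@H](c1ccc(O)cc1)O2`: 92%

In a functional assay on PC-3 cells (Homo sapiens) for inhibition, read by sulforhodamine B assay, with a stated time of 48 h, tested at 50 uM (on this read-out lower numbers stand for less inhibition of growth and higher numbers for more inhibition of growth at the one concentration tested), compound 1 gives 53%, the second highest of the three numbers. Compound 2 gives 22%, a number lower than compound 1 by a gap beyond the scatter, while compound 3 gives 92%, higher than compound 1 by a gap beyond the scatter. Compound 4 `CCCCOc1ccc([C@@H]2CC(=O)c3cc(CC=C(C)C)c(OC)cc3O2)cc1` has not been measured in this assay; it differs from compound 1 by butyl in place of phenyl on an oxygen on an aromatic ring. For the measured compounds named here, no pair of measured compounds differs in only one place, so the size of such a step has to be guessed. The change from compound 1 to compound 4 is expected to give a step of a number 3 percentage points lower from compound 1 to compound 4 (within the scatter), that is, nothing beyond the scatter. Compound 4 is therefore estimated at 50%, in the range 30% to 70%.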

Compound 4, percent growth inhibition at one concentration: 48%
For compound 4 the middle estimate is 2 percentage points above the measured one; the measured number falls inside the stated range.
By their numbers in this assay, from the lowest: compound 2; then compounds 4 and 1 (each within the scatter of the next); then compound 3.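

In this assay, the exchange of phenyl for butyl on the oxygen on an aromatic ring gives a number 5 percentage points lower from compound 1 to compound 4 (within the scatter). For the compounds shown here, this is the first single-place step available at this position, and it shows that the phenoxy group can give way to butoxy, a ring to an open chain, without a change beyond the scatter. No measurement shown here offers an explanation for this result.

Going by these compounds, whether a chain longer than butyl, or a butyl chain ending in an amine or a carboxylic acid, would leave the number equally unchanged stays open. So does whether this holds at other concentrations.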